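The compounds below may be only part of what the source reports. "The series", "measured", "known", "first", "only" and "open" are said of these compounds alone.

Compound 1 `COc1ccc(-c2cn3ccnc3c(-c3ccc4ncn(C5CCCCC5)c4c3)n2)cc1`: -20.9%
Compound 2 `O=Cc1ccc(-c2cn3ccnc3c(-c3ccc4ncn(C5CCCCC5)c4c3)n2)cc1`: 25.3%

Both compounds share one core and were tested in a functional assay on NCI-H522 cells (Homo sapiens) for inhibition, read by sulforhodamine B assay, with a stated time of 48 h, tested at 10 uM; on this read-out higher numbers stand for more inhibition at the one concentration tested (going by the name of the read-out) and lower numbers for less inhibition. Compound 2 stands highest of the two numbers, and compound 1 sits below it by a number 46.2 percentage points higher from compound 1 to compound 2 (beyond the scatter), a large step that came from putting a formyl in place of a methoxy on an aromatic carbon.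

Compound 3 `c1ccc2c(-c3cn4ccnc4c(-c4ccc5ncn(C6CCCCC6)c5c4)n3)cccc2c1` has not yet been measured in this assay. It differs from compound 2 as follows: naphthalen-1-yl in place of 4-formylphenyl on an aromatic carbon. Among the measured compounds shown here, the only measured step, a number 46.2 percentage points higher from compound 1 to compound 2 (beyond the scatter), is the one that bears on this change, since compound 3 gives up the formyl group that compound 2 carries but does not bring the methoxy of compound 1 back either. For the measured compounds named here, with no measured pair in which a naphthalen-1-yl replaces a substituted phenyl, the direction is uncertain, yet the loss of the formyl that went with a number 46.2 percentage points higher from compound 1 to compound 2 (beyond the scatter) suggests a fall; the expected step is a number 20.3 percentage points lower from compound 2 to compound 3 (beyond the scatter). Compound 3 is therefore estimated at 5% in this assay, with a range from -25% to 35%.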

Compound 3, a percentage reported as inhibition, at one concentration (the size of the read-out at that concentration, not a potency): 19.3%
Beside the measured number, compound 3's estimate is 14.3 percentage points below it; measured number inside the range.
By their numbers in this assay, from the lowest: compound 1; then compounds 3 and 2 (each within the scatter of the next).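

Putting naphthalen-1-yl in place of 4-formylphenyl gives a number 6 percentage points lower from compound 2 to compound 3 (within the scatter) in this assay, so at this aromatic carbon the formyl group is not required for a reading at the level of compound 2, and an all-carbon group with two aromatic rings serves as well. Putting naphthalen-1-yl in place of 4-methoxyphenyl gives a number 40.2 percentage points higher from compound 1 to compound 3 (beyond the scatter), which makes compound 1, with its 4-methoxyphenyl, the one that stands apart among the three, rather than compound 2 with its formyl. Nothing available here accounts for why the 4-methoxyphenyl group differs from the other two groups.

Still open, as far as these compounds go, is whether a plain phenyl, or a phenyl carrying an amine or a carboxylic acid at the same place, would read like compound 1 or like compound 2 and compound 3. Also open, from the compounds shown here alone, is whether naphthalen-2-yl would match naphthalen-1-yl, and whether these readings would hold if a longer chain replaced the cyclohexyl group that all three compounds share.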